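Moving the fluorine on the pendant phenyl of compound 1

The source may hold more compounds than are shown below. What is called first, only, known or untested is meant among the compounds shown, and "the series" means these compounds.

Compound 1 `O=S(=O)(c1ccc(F)cc1)c1cnc2cc(F)ccc2c1-c1cccc(F)c1` gives 0.95 mL/min in an ADME assay on microsomes from liver (Homo sapiens) for metabolic stability, tested at 2.5 uM; on this read-out higher numbers stand for fast clearance and lower numbers for slow clearance. Compound 2 `COc1cccc(S(=O)(=O)c2cnc3cc(F)ccc3c2-c2cccc(F)c2)c1` gives 3.36 mL/min. Compound 3 `O=S(=O)(c1cc(F)cc(F)c1)c1cnc2cc(F)ccc2c1-c1cccc(F)c1` gives 0.06 mL/min.

Compound 1 stands second highest of the three numbers; its nearest neighbour is compound 2, a step of a 3.5-fold higher number from compound 1 to compound 2 (0.55 log units; beyond the scatter), and its furthest is compound 3, a step of a 16-fold lower number from compound 1 to compound 3 (1.20 log units; beyond the scatter). Between compounds 2 and 3 the step is a 56-fold lower number from compound 2 to compound 3 (1.75 log units; beyond the scatter). All three measured steps change the aryl group on the sulfonyl sulfur.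

Compound 4 `O=S(=O)(c1ccc(F)cc1)c1cnc2cc(F)ccc2c1-c1ccc(F)cc1` differs from compound 1 elsewhere: 4-fluorophenyl in place of 3-fluorophenyl on an aromatic carbon. Among the measured compounds shown here, no measured step touches this position, so nothing among the measured compounds tells how the read-out responds to this change. The expectation therefore rests on compound 1 alone, and compound 4 is expected to stay within the scatter of compound 1, a step of a 1.1-fold higher number from compound 1 to compound 4 (0.02 log units; within the scatter). Compound 4 is estimated at 1 mL/min, with a range from 0.4 mL/min to 2.5 mL/min.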

Compound 4, intrinsic clearance in a liver preparation (reported as CLH), per the amount of preparation that the assay uses: 1.34 mL/min
The estimate for compound 4 lay 1.3-fold (0.13 log units) below the measured number, and the stated range covers the measured number.
By their numbers in this assay, from the lowest: compound 3; then compounds 1 and 4 (each within the scatter of the next); then compound 2.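

Among the compounds shown here, until this point, every measured step had changed the aryl group on the sulfonyl sulfur, so this is the first reading at the aromatic carbon of the shared core. In this assay, putting 4-fluorophenyl in place of 3-fluorophenyl there gives a small step (a 1.4-fold higher number from compound 1 to compound 4 (0.15 log units; within the scatter)), whereas each step among the groups on the sulfonyl sulfur lay beyond the scatter. Nothing in the data shown accounts for this result.

The compounds shown leave open how the read-out responds at this position to a group other than a fluorophenyl, such as a pyridine ring, or to an amine or a carboxylic acid carried on the phenyl ring. They also leave open whether the 3,5-difluorophenyl group on the sulfonyl sulfur would give a similar step alongside 4-fluorophenyl at this position.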